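Shortening the ester chain of the malonamide series

The compounds below may be only part of what the source reports. "The series", "measured", "known", "first", "only" and "open" are said of these compounds alone.

Going by the values given here, in an assay on microsomes from intestine for inhibition of acyl-CoA:cholesterol acyltransferase (Oryctolagus cuniculus) (on this read-out higher numbers stand for weaker inhibition and lower numbers for stronger inhibition), compound 2 `CCCCCCCCCCOC(=O)CC(=O)Nc1c(C(C)C)cccc1C(C)C` gives 53 nM, the only number in the set. Compound 1 `CC(C)c1cccc(C(C)C)c1NC(=O)CC(=O)OC(c1ccccc1)c1ccccn1` reaches only a limit of the assay, > 5000 nM, in this assay, as noted in the limit of > 5000 nM in this assay, at which 1 of the 2 values shown sits. Compound 3 `CCCCCCOC(=O)CC(=O)Nc1c(C(C)C)cccc1C(C)C` is compound 2 with hydrogen in place of butyl on a saturated chain carbon, six bonds along the chain from an oxygen next to a carbonyl group. Among the compounds with values here, no measured step covers this change, so the expectation rests on compound 2 alone; a step toward weaker inhibition, somewhat beyond the scatter, is expected. The expected size of the step is a 3.8-fold higher number from compound 2 to compound 3 (0.58 log units; beyond the scatter). Compound 3 is therefore estimated at 200 nM, with a range from 60 nM to 800 nM.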

Compound 3, half-maximal inhibitory concentration: 810 nM
Beside the measured number, compound 3's estimate is 4.1-fold (0.61 log units) below it, and the stated range ends below it.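

In this assay the saturated chain carbon six bonds along the chain from an oxygen next to a carbonyl group is a sensitive place: hydrogen in place of butyl there gives a 15-fold higher number from compound 2 to compound 3 (1.18 log units; beyond the scatter) as the first step read in this series. Length of the ester chain therefore counts strongly between these two compounds. Nothing shown accounts for a step of this size.

On these data alone, whether potency falls gradually or abruptly across the chains between compound 2 and compound 3 stays open. Also open, as far as these compounds go, is how a longer chain, or a chain carrying a carboxylic acid, would read.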